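The source may hold more compounds than are shown below. What is called first, only, known or untested is meant among the compounds shown, and "the series" means these compounds.

Compound 1, `CN(C)c1nc(/C=C/c2ccccc2)nc2ccsc12`: > 1000000 nM in a functional assay on L02 cells (Homo sapiens) for inhibition, read by Griess assay, with stated times of 1 h and 24 h; a higher number here means a weaker inhibitor, a lower number a stronger inhibitor
Compound 2, `CN1CCN(c2nc(/C=C/c3ccccc3)nc3ccsc23)CC1`: 198000 nM
Compound 3, `CN(c1ccccc1)c1nc(/C=C/c2ccccc2)nc2ccsc12`: > 1000000 nM

Compound 3 stands at the edge of what this assay can report: its value, > 1000000 nM, is a limit and not a number. Compound 1 sits at the same limit, > 1000000 nM. Compound 2 is the only one of the three with a measured number, and the step of an at least 5.0-fold higher number from compound 2 to compound 3 (0.70 log units; beyond the scatter) shows compound 3 to be the weaker of the pair. The step that the two limits leave unreadable from compound 1 to compound 3 cannot be read, since both ends are limits (the limit of > 1000000 nM in this assay, at which 2 of the 3 values shown sit).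

Compound 4, `Brc1cccc(Nc2nc(/C=C/c3ccccc3)nc3ccsc23)c1`, differs from compound 3 by (3-bromophenyl)amino in place of methyl(phenyl)amino on an aromatic carbon. Among the measured compounds shown here, no measured step covers a change of this kind: the two readable steps, an at least 5.0-fold lower number from compound 1 to compound 2 (0.70 log units; beyond the scatter) and an at least 5.0-fold higher number from compound 2 to compound 3 (0.70 log units; beyond the scatter), both concern the 4-methylpiperazin-1-yl group rather than a substituted phenyl on the nitrogen. With compound 3 only known as a limit, the expectation for compound 4 is wide. Compound 4 is estimated at 400000 nM, between 60000 nM and 1000000 nM, with a step of an at least 2.5-fold lower number from compound 3 to compound 4 (0.39 log units; beyond the scatter) expected that may well again end at the limit.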

Compound 4, half-maximal inhibitory concentration: > 1000000 nM
Compound 4: only a limit was reported; the forecaster's own chance of this, stated with the estimate: 50%; middle value at least 2.5-fold (0.39 log units) from the limit.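

In this assay, the (3-bromophenyl)amino group on this aromatic carbon brings a bromine and a hydrogen-bond donor that the methyl(phenyl)amino group lacks, yet compound 4 still reads only as a limit, as do compound 1 and compound 3. The one readable step, an at least 5.0-fold higher number from compound 2 to compound 4 (0.70 log units; beyond the scatter), leaves the 4-methylpiperazin-1-yl group as the only group shown here that gives a measured number. The steps from compound 1 and from compound 3 to compound 4 cannot be read, since both ends of each are limits: the limit of > 1000000 nM in this assay, at which 3 of the 4 values shown sit.

Going by these compounds, it remains open whether the number for compound 2 depends on the piperazine ring as a whole or on its methylated nitrogen. A morpholine or a piperazine without the methyl group at this position would bear on that question.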